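The source may report more compounds than this note shows. Statements on the series, on what has been measured and on what is new or still open speak of the compounds shown alone.

Compound 1 `Cc1ccccc1S(=O)(=O)Nc1ccc2oc(-c3ccccc3)nc2c1` gives 57000 nM in an ADME assay on HEK293 cells (Homo sapiens) for cytotoxicity, read by resazurin assay, with a stated time of 48 h; on this read-out higher numbers stand for lower toxicity in this test and lower numbers for higher toxicity in this test.
Compound 2 `O=S(=O)(Nc1ccc(-c2nc3ccccc3o2)cc1)c1cccc(C(F)(F)F)c1` gives > 100000 nM in this assay.

Among the measured compounds shown here, compound 1 carries the only plain number in this assay. The entry for compound 2 is a limit of the assay and not a number, (the limit of > 100000 nM in this assay, at which 1 of the 2 values shown sits). Compound 3 `O=S(=O)(Nc1ccc2oc(-c3ccccc3)nc2c1)c1ccc(Cl)s1` differs from compound 1 by 5-chlorothiophen-2-yl in place of 2-methylphenyl on a sulfonyl sulfur. For the measured compounds named here, no measured pair shows the effect of such a change, so the step of a 1.1-fold higher number from compound 1 to compound 3 (0.02 log units; within the scatter) is expected to stay within the usual scatter, with neither direction favoured. Compound 3 is therefore estimated at 60000 nM in this assay, within a range from 25000 nM to 150000 nM.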

Compound 3, half-maximal cytotoxic concentration: > 100000 nM
Compound 3: only a limit was reported; the forecaster's own chance of this, stated with the estimate: 30%; middle value at least 1.6-fold (0.22 log units) away from the limit.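

Placing 5-chlorothiophen-2-yl instead of 2-methylphenyl on the sulfonyl sulfur gives an at least 1.7-fold higher number from compound 1 to compound 3 (0.24 log units; that floor lies within the scatter), the first direct reading of a change at this position in this assay. The entry for compound 3 is a limit of the assay and not a number, and the true size of the step stays unknown because the readings end there: the limit of > 100000 nM in this assay, at which 2 of the 3 values shown sit.

Going by these compounds, what remains open is how other groups on the sulfonyl sulfur would read, such as a short alkyl chain or a phenyl ring carrying an amine or a carboxylic acid.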